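Urea series: trimming one alkyl group on compound 1

The source may report more compounds than this note shows. Statements on the series, on what has been measured and on what is new or still open speak of the compounds shown alone.

Measured in an assay on microsomes from intestine for inhibition of acyl-CoA:cholesterol acyltransferase (Oryctolagus cuniculus); a higher number here means a weaker inhibitor, a lower number a stronger inhibitor:
compound 1 `CC(C)c1cccc(C(C)C)c1NC(=O)NCC1(c2ccccc2)CCCCC1` gives 21 nM
compound 2 `O=C(NCC1(c2ccccc2)CCCCC1)Nc1ccc(Cl)cc1` gives 2200 nM

Compound 1 has the lowest number of the two; compound 2 sits far higher, well beyond the scatter. Compound 3 `CCc1cccc(C(C)C)c1NC(=O)NCC1(c2ccccc2)CCCCC1` keeps the core of compound 1 and differs only by hydrogen in place of methyl on a saturated chain carbon bound to an aromatic carbon and a saturated chain carbon, that is, isopropyl to ethyl. Among the measured compounds shown here, no measured pair isolates this change. In this assay a small step toward a higher number is expected, possibly within the scatter, so the step from compound 1 to compound 3 is estimated at a 1.9-fold higher number from compound 1 to compound 3 (0.28 log units; within the scatter). Compound 3 is expected to give about 40 nM, in the range 15 nM to 120 nM.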

Compound 3, half-maximal inhibitory concentration: 20 nM
For compound 3 the middle estimate is 2.0-fold (0.30 log units) above the measured one, within the range that was stated.
By their numbers in this assay, from the lowest: compounds 3 and 1 (each within the scatter of the next); then compound 2.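

In this assay, among the compounds shown here, isopropyl to ethyl at this position gives a 1.1-fold lower number from compound 1 to compound 3 (0.02 log units; within the scatter) and is the only single-place comparison. On this one pair, hydrogen can stand in place of methyl on that saturated chain carbon with no readable difference in the number. No measured evidence bears on why this is so.

As far as these compounds go, whether a methyl group, a tert-butyl group or a longer chain would hold the number at this position stays open. So does the effect of making the same change to the remaining isopropyl group of compound 3.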